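The compounds below may be only part of what the source reports. "The series", "measured", "known", "first", "only" and "open" are said of these compounds alone.

Measured compounds:
Compound 1 `COc1ccc(Nc2nc(-c3cccc(F)c3)nc3ccc(F)cc23)cc1` gives 42300 nM in a functional assay on HT29-AK cells (Homo sapiens) for cytotoxicity, read by MTT assay, with a stated time of 48 h; on this read-out higher numbers stand for weaker inhibition and lower numbers for stronger inhibition.
Compound 2 `Fc1cccc(-c2nc(Nc3ccc(Br)cc3)c3cc(F)ccc3n2)c1` gives only the limit > 50000 nM in this assay.
Compound 3 `Fc1cccc(-c2nc(Nc3cccc(Br)c3)c3cc(F)ccc3n2)c1` gives only the limit > 50000 nM in this assay.

Among the measured compounds shown here, compound 1 holds the only number; the other two values sit at the limit of > 50000 nM in this assay, at which 2 of the 3 values shown sit. Compound 4 `Cc1cccc(Nc2nc(-c3cccc(F)c3)nc3ccc(F)cc23)c1` differs from compound 1 by 3-methylphenyl in place of 4-methoxyphenyl on a nitrogen on an aromatic ring. Two measured steps replace the same aryl group on that nitrogen: an at least 1.1-fold higher number from compound 1 to compound 2 (0.07 log units; that floor lies within the scatter) and an at least 1.1-fold higher number from compound 1 to compound 3 (0.07 log units; that floor lies within the scatter), each ending at the limit. Given an at least 1.1-fold higher number from compound 1 to compound 2 (0.07 log units; that floor lies within the scatter) and an at least 1.1-fold higher number from compound 1 to compound 3 (0.07 log units; that floor lies within the scatter), the step to compound 4 is expected to be small or to run toward the limit, with a real chance that this assay again reports only a limit. Compound 4 is therefore expected at 50000 nM (range 20000 nM to 150000 nM), an expected step of a 1.2-fold higher number from compound 1 to compound 4 (0.07 log units; within the scatter).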

Compound 4, half-maximal inhibitory concentration: > 50000 nM
Compound 4: a limit, no number; the forecaster's own chance of this, stated with the estimate: 55%; the middle value sits exactly at the limit.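

The change to 3-methylphenyl gives an at least 1.1-fold higher number from compound 1 to compound 4 (0.07 log units; that floor lies within the scatter) in this assay and extends the pattern on this nitrogen beyond bromo-substituted rings to a ring carrying only methyl. The steps from compound 2 and compound 3 to compound 4 cannot be read, so methyl and bromo cannot be ordered. The series now gathers at a single ceiling: the limit of > 50000 nM in this assay, at which 3 of the 4 values shown sit.

Whether any replacement for 4-methoxyphenyl truly differs from it stays unresolved. Also open, on these data alone, is whether an amine or a carboxylic acid on this aryl ring would give a number rather than a limit.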